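Replacing the side group on compound 1

The source may hold more compounds than are shown below. What is called first, only, known or untested is meant among the compounds shown, and "the series" means these compounds.

In a functional assay (aorta) for inhibition, with Rattus norvegicus as the target (a lower number here means a stronger inhibitor, a higher number a weaker inhibitor), compound 1 `CC(C)/N=C(\S)[C@]1(c2cccnc2)CCCC[S+]1[O-]` gives 10000 nM and compound 2 `CCCC/N=C(\S)[C@]1(c2cccnc2)CCCC[S+]1[O-]` gives 8000 nM. These two numbers stand level, with a 1.3-fold lower number from compound 1 to compound 2 (0.10 log units; within the scatter). Compound 3 `[O-][S+]1CCCC[C@]1(/C(S)=N/c1ccccc1)c1cccnc1` is reported only as a limit, > 30000 nM. Compound 1 therefore sits with compound 2 among the two numerical values in the set.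

The next step leads to compound 4 `COC(=N)[C@]1(c2cccnc2)CCCC[S+]1[O-]`, and the change is a group of 4 heavy atoms (2 carbon, 1 nitrogen, 1 oxygen; no ring) in place of a group of 6 heavy atoms (4 carbon, 1 nitrogen, 1 sulfur; no ring), on a saturated ring carbon. The group is replaced on a saturated ring carbon, next to the ring sulfur.

The three measured steps bear on this only indirectly, since each changes just the substituent on the double-bonded nitrogen. Butyl in place of isopropyl gave a 1.3-fold lower number from compound 1 to compound 2 (0.10 log units; within the scatter). Phenyl gave an at least 3.0-fold higher number from compound 1 to compound 3 (0.47 log units; beyond the scatter) and also an at least 3.7-fold higher number from compound 2 to compound 3 (0.57 log units; beyond the scatter). For the measured compounds named here, no measured step replaces the whole group, so the size of the new step is poorly bounded. Going by the values given here, the only steps beyond the scatter, an at least 3.0-fold higher number from compound 1 to compound 3 (0.47 log units; beyond the scatter) and an at least 3.7-fold higher number from compound 2 to compound 3 (0.57 log units; beyond the scatter), run towards a higher number, and a move in that direction is expected here too, though with low confidence.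

The expected step is a 2.0-fold higher number from compound 1 to compound 4 (0.30 log units; within the scatter). For compound 4 the estimated value is 20000 nM, with an expected range from 6000 nM to 60000 nM.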

Compound 4, concentration for 90% inhibition: > 30000 nM
Compound 4 was reported as a limit (the forecaster's own chance of this, stated with the estimate: 50%); at least 1.5-fold (0.17 log units) between middle value and limit.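

In this assay, for the compounds shown here, this is the first step on the saturated ring carbon, next to the ring sulfur, that replaces the whole group rather than only the substituent on the double-bonded nitrogen, and it gives an at least 3.0-fold higher number from compound 1 to compound 4 (0.47 log units; beyond the scatter). A move beyond the scatter is therefore no longer tied to phenyl on that nitrogen: a group of 4 heavy atoms with no ring, holding oxygen and no sulfur, also leaves the numerical range set by compound 1 and compound 2. How far the number moves cannot be read, and compound 4 cannot be placed against compound 3 either: the limit of > 30000 nM in this assay, at which 2 of the 4 values shown sit.

Compound 4 alters the size of the group, swaps sulfur for oxygen and drops the nitrogen substituent in one step, so the compounds shown do not tell which of these changes carries the shift. Also open, going by these compounds, is how a carboxylic acid or a primary amine on this ring carbon would read in this assay, and whether any group there can give a clearly lower number than compound 1.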